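From (pyridin-2-yl)methyl to cycloheptyl in a cell assay

The source may report more compounds than this note shows. Statements on the series, on what has been measured and on what is new or still open speak of the compounds shown alone.

In an ADME assay on MRC5 cells (Homo sapiens) for inhibition, with a stated time of 72 h (a lower number here means that less compound is needed, a higher number that more compound is needed for the effect), compound 3 (`COc1cccc(OC)c1C(=O)Nc1c[nH]nc1C(=O)NCc1ccccn1`) reads > 50000 nM, which is a limit of the assay and not a number. Compound 4 (`COc1cccc(OC)c1C(=O)Nc1c[nH]nc1C(=O)NC1CCCCCC1`) has not yet been measured. It has cycloheptyl in place of (pyridin-2-yl)methyl on an amide-type nitrogen. Going by the values given here, no measured pair isolates this change, so any forecast is loose. Compound 1 (`CO[C@H]1CC[C@H](NC(=O)c2n[nH]cc2NC(=O)c2ccc(OC(F)F)cc2)CC1`) gives 2500 nM and compound 2 (`CO[C@H]1CC[C@H](NC(=O)c2n[nH]cc2NC(=O)c2ccccc2C(F)(F)F)CC1`) gives 3300 nM. Neither carries (pyridin-2-yl)methyl, though both also differ from compound 3 elsewhere. A sizeable move towards less compound needed therefore seems likely. The expected step is an at least 5.0-fold lower number from compound 3 to compound 4 (0.69 log units; beyond the scatter). Compound 4 is estimated at 10000 nM, with an expected range of 2000 nM to 45000 nM.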

Compound 4, half-maximal effective concentration: 42000 nM
The estimate for compound 4 lay 4.2-fold (0.62 log units) below the measured number; the range from low to high includes it.
By their numbers in this assay, from the lowest: compounds 1 and 2 (each within the scatter of the next); then compound 4. At a limit, above all of these: compound 3.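

In this assay compound 4, with cycloheptyl in place of (pyridin-2-yl)methyl on an amide-type nitrogen, gives a number that can be read. Compound 3 reads > 50000 nM, which is a limit of the assay and not a number. The change can therefore be stated only as a floor, an at least 1.1-fold lower number from compound 3 to compound 4 (0.07 log units; that floor lies within the scatter), because compound 3 sits at the limit: the limit of > 50000 nM in this assay, at which 1 of the 4 values shown sits.

Still open, going by these compounds, is whether the hetero atom, the aromatic ring or the ring size matters at this position. Benzyl or cyclohexyl on that nitrogen would each make a smaller change than this swap.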